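A few compounds are considered here, and "the series" means these few. Any claim that something is new, unique, unknown or untested is made for them only; others in the source may bear on it.

Compound 3 `CCCC1CCN(CCCCC(=O)c2cc(Cl)c(N)cc2OCc2cc(OC)cc(OC)c2)CC1` gives 7.7 in a functional assay for antagonist activity at 5-hydroxytryptamine receptor 4 (Rattus norvegicus) (on this read-out higher numbers stand for higher potency (the scale is a negative logarithm) and lower numbers for lower potency), the highest of the two numbers shown. Compound 2 `COc1ccc(CCOc2cc(N)c(Cl)cc2C(=O)CCCCN2CCCCC2)cc1OC` gives 6.8 in this assay, a value that stands under compound 3 beyond the scatter. Compound 1 `CCOc1cc(N)c(Cl)cc1C(=O)CCCCN1CCCCC1` gives only a limit in this assay, namely < 7, as noted in the limit of < 7 in this assay, at which 1 of the 3 values shown sits. The step that the limit leaves unreadable from compound 1 to compound 2 is therefore not readable in size. Compound 4 `COc1cc(COc2cc(N)c(Cl)cc2C(=O)CCCCN2CCC(O)CC2)cc(OC)c1` differs from compound 3 by hydroxy in place of propyl on a saturated ring carbon. Among the compounds with values here, no measured step touches this saturated ring carbon; the only step between measured compounds concerns a group two bonds along the chain from an oxygen on an aromatic ring and is unreadable. Compound 4 is nonetheless expected to lose some potency, a step of a number 0.70 log units lower from compound 3 to compound 4 (beyond the scatter), and is estimated at 7, between 6.3 and 7.7.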

Compound 4, negative logarithm of the antagonist equilibrium constant: 8.3
For compound 4 the middle estimate is 1.30 log units below the measured one; measured number outside the range, above it.
By their numbers in this assay, from the lowest: compound 2; then compound 3; then compound 4.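

Within the data shown here, the change from 4-propylpiperidin-1-yl to 4-hydroxypiperidin-1-yl gives a number 0.60 log units higher from compound 3 to compound 4 (beyond the scatter) in this assay and is the only readable step at this saturated ring carbon. It shows that potency here does not depend on the propyl: the smaller hydroxy, with one hydrogen-bond donor and one acceptor, does better. Nothing given here accounts for this rise. From the compounds shown here alone, whether an amine or a methoxy on this ring carbon would match the hydroxy remains open. So does whether a longer chain in place of the propyl would lower potency.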